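Bicyclic amine variation on the quinolinyl amide series

The compounds below may be only part of what the source reports. "The series", "measured", "known", "first", "only" and "open" are said of these compounds alone.

Measured compounds:
- compound 1, `O=C(CCc1ccc(C(F)(F)F)cc1)Nc1ccc2nc(N3CC4CC3CN4)ccc2c1`: 210 nM
- compound 2, `CN(c1ccc2cc(NC(=O)CCc3ccc(C(F)(F)F)cc3)ccc2n1)C1CCCC1`: 2 nM
- compound 3, `O=C(CCc1ccc(C(F)(F)F)cc1)Nc1ccc2nc(N3CC4CC3CO4)ccc2c1`: 13 nM

All three share one core and differ only in the amine on the aromatic carbon next to the ring nitrogen. In an assay on isolated protein for displacement of a labelled ligand from melanin-concentrating hormone receptor 1 (Homo sapiens) (a higher number here means a weaker inhibitor, a lower number a stronger inhibitor), compound 3 sits in the middle of the three: a 6.5-fold higher number from compound 2 to compound 3 (0.81 log units; beyond the scatter), while a 16-fold lower number from compound 1 to compound 3 (1.21 log units; beyond the scatter).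

Compound 4, `O=C(CCc1ccc(C(F)(F)F)cc1)Nc1ccc2nc(N3CC4CCC3CC4)ccc2c1`, is not yet measured. Relative to compound 3 the change is a group of 8 heavy atoms (7 carbon, 1 nitrogen; 2 six-membered non-aromatic rings with 1 hetero atom each) in place of a group of 7 heavy atoms (5 carbon, 1 nitrogen, 1 oxygen; 2 five-membered non-aromatic rings with 1 hetero atom each), on an aromatic carbon, again on the aromatic carbon next to the ring nitrogen, meta and para to the fused ring.

Among the measured compounds shown here, the step that bears most directly on this is the one between compound 2 and compound 3: a 6.5-fold higher number from compound 2 to compound 3 (0.81 log units; beyond the scatter), so removing the oxygen-containing bicycle in favour of a carbon-only amine lowered the number by a modest amount. The step of a 16-fold lower number from compound 1 to compound 3 (1.21 log units; beyond the scatter) points the same way, toward fewer hetero atoms giving lower numbers. For the measured compounds named here, compound 4 brings a carbon-only bicycle, so a modest step down in this assay is expected, a 2.6-fold lower number from compound 3 to compound 4 (0.41 log units; beyond the scatter), though the larger ring size has no precedent in the three compounds. For compound 4 the estimate is 5 nM, with a range from 1.5 nM to 20 nM.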

Compound 4, half-maximal inhibitory concentration: 3 nM
Beside the measured number, compound 4's estimate is 1.7-fold (0.22 log units) above it; low and high end bracket the measured number.
By their numbers in this assay, from the lowest: compounds 2 and 4 (each within the scatter of the next); then compound 3; then compound 1.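

In this assay, the carbon-only bicyclic amine of compound 4 gives a low number at this aromatic carbon next to the ring nitrogen (a 4.3-fold lower number from compound 3 to compound 4 (0.64 log units; beyond the scatter)), and the gap to the diamine of compound 1 is large (a 70-fold lower number from compound 1 to compound 4 (1.85 log units; beyond the scatter)). A bicyclic amine with a single nitrogen as its only hetero atom therefore sits with the open amine of compound 2, and the two cannot be ordered (a 1.5-fold higher number from compound 2 to compound 4 (0.18 log units; within the scatter)), which is within the scatter. No measurement shown here accounts for these steps.

The step from compound 3 changes ring size and removes the oxygen at once, so the compounds shown do not separate the two changes. A six-membered bicyclic amine carrying an oxygen, a plain piperidine or a morpholine at this carbon would bear on that question.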